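Removing the methoxy group from compound 3: an expectation

The source may hold more compounds than are shown below. What is called first, only, known or untested is meant among the compounds shown, and "the series" means these compounds.

Measured so far:
compound 1, `Cc1ccc(-c2n[nH]cc2N2CCCNCC2)cc1`, 744 nM
compound 2, `COc1ccccc1-c1n[nH]cc1N1CCCNCC1`, 2230 nM
compound 3, `COc1cccc(-c2n[nH]cc2N2CCCNCC2)c1`, 1030 nM

Of the compounds shown here, three sharing one core have been tested in an assay on isolated protein for binding affinity to 5-hydroxytryptamine receptor 3A (Homo sapiens); on this read-out lower numbers stand for stronger inhibition and higher numbers for weaker inhibition. Compound 1 gives 744 nM, compound 2 gives 2230 nM and compound 3 gives 1030 nM. Compound 3 therefore stands second highest of the three numbers: its nearest neighbour is compound 1, whose value lies within the scatter of repeated measurements, while compound 2 lies furthest away, beyond the scatter.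

The next compound, compound 4 (`c1ccc(-c2n[nH]cc2N2CCCNCC2)cc1`), has not yet been measured in this assay. It differs from compound 3 in one place: hydrogen in place of methoxy on an aromatic carbon. For the measured compounds named here, no step between two measured compounds reproduces this change, so the size of the step can only be guessed. The three measured values all fall within a narrow band, with compound 1 and compound 3 close together, which suggests that losing the methoxy group is unlikely to move the number far.

For compound 4 the expected step from compound 3 is a 1.1-fold lower number from compound 3 to compound 4 (0.06 log units; within the scatter), a small move towards a lower number that would still sit inside the scatter. On that basis compound 4 is estimated to give 900 nM in this assay, with a range from 400 nM to 2000 nM.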

Compound 4, inhibition constant: 2100 nM
The estimate for compound 4 lay 2.3-fold (0.37 log units) below the measured number; the measured number lies above the stated range.
By their numbers in this assay, from the lowest: compounds 1 and 3 (each within the scatter of the next); then compounds 4 and 2 (each within the scatter of the next).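

In this assay the step of a 2.0-fold higher number from compound 3 to compound 4 (0.31 log units; beyond the scatter) shows that the methoxy group on this aromatic carbon, meta to a large group, does count: the unsubstituted ring does not keep the number of the methoxy compound. Hydrogen in place of methyl moves the same way, with a 2.8-fold higher number from compound 1 to compound 4 (0.45 log units; beyond the scatter) and a modest size, so the two compounds in the low pair each stand apart from the unsubstituted ring by a step beyond the scatter. The other methoxy compound goes against any rule for methoxy as such. The same exchange there gives a 1.1-fold lower number from compound 2 to compound 4 (0.03 log units; within the scatter) and so leaves the number inside the scatter, which means that what the methoxy group is worth here depends on where it stands on the ring.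

Nothing available gives a reason for this difference between the two methoxy compounds. From the compounds shown here alone, it also remains open whether a hydroxyl group, a fluorine atom or an amine on this same aromatic carbon would hold the number of compound 3, or whether a longer chain such as ethoxy would take it further.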